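Cyclohexyl for cyclopropyl on the shared isoxazole-bearing core

The compounds below may be only part of what the source reports. "The series", "measured", "known", "first", "only" and "open" are said of these compounds alone.

Compound 2 `CC(C)n1nc(-c2cc(C3CC3)on2)c(C(N)=O)c1N` holds the lowest number of the two measured in an assay on isolated protein for inhibition of proto-oncogene tyrosine-protein kinase receptor Ret (Homo sapiens), read by radiometric assay and 33P incorporation, in the presence of a further agent that is not named here (on this read-out lower numbers stand for stronger inhibition and higher numbers for weaker inhibition), where compound 2 gives 44 nM. Its nearest neighbour is compound 1 `Cc1ccc(-c2cc(-c3nn(C(C)C)c(N)c3C(N)=O)no2)cc1`, which in this assay gives 1660 nM; the step of a 38-fold lower number from compound 1 to compound 2 (1.58 log units; beyond the scatter) is the only one recorded, and it came with cyclopropyl in place of 4-methylphenyl on an aromatic carbon. Compound 3 `CC(C)n1nc(-c2cc(C3CCCCC3)on2)c(C(N)=O)c1N` differs from compound 2 in one place: cyclohexyl in place of cyclopropyl on an aromatic carbon. For the measured compounds named here, the one measured step shows that the group on this aromatic carbon matters greatly, and that the smaller cyclopropyl was far better than the larger 4-methylphenyl. Going by the values given here, compound 3 carries a group larger than cyclopropyl, so a move toward a higher number is expected, though cyclohexyl is not aromatic and the single step gives no direct measure for it. For compound 3 the expected step is a 3.6-fold higher number from compound 2 to compound 3 (0.56 log units; beyond the scatter), giving an estimate of 160 nM with a range from 40 nM to 650 nM.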

Compound 3, half-maximal inhibitory concentration: 2700 nM
For compound 3 the middle estimate is 17-fold (1.23 log units) below the measured one; the measured number lies above the stated range.
By their numbers in this assay, from the lowest: compound 2; then compounds 1 and 3 (each within the scatter of the next).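

In this assay, the step of a 61-fold higher number from compound 2 to compound 3 (1.79 log units; beyond the scatter) shows that the high number at this position does not depend on an aromatic group: cyclohexyl, a six-membered non-aromatic ring of carbon only, also fails to keep what cyclopropyl gives. The step of a 1.6-fold higher number from compound 1 to compound 3 (0.21 log units; within the scatter) places cyclohexyl and 4-methylphenyl within the scatter of each other, so among the three groups shown, cyclopropyl alone gives the low number. Nothing available explains this difference.

The compounds shown leave open where between the three-membered and six-membered rings the number rises, which cyclobutyl or cyclopentyl on this carbon would help to settle. They also leave open whether the ring itself is needed, as an open chain such as isopropyl or a single methyl would test.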